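A few compounds are considered here, and "the series" means these few. Any claim that something is new, unique, unknown or untested is made for them only; others in the source may bear on it.

Measured in an assay on microsomes from brain for inhibition of Fatty-acid amide hydrolase 1 (Rattus norvegicus), read by fluorescence and HPLC, with a stated time of 60 min; on this read-out higher numbers stand for weaker inhibition and lower numbers for stronger inhibition:
compound 1 `CCCCCCCCc1ccc(OCC(=O)Cn2nnc(-c3cccnc3)n2)cc1` gives 23 nM
compound 2 `CCCCCCCCc1ccc(OCC(=O)Cn2nnc(-c3cccc(C(=O)O)c3)n2)cc1` gives 36 nM
compound 3 `CCCCCCCCc1ccc(OCC(=O)Cn2nnnc2-c2ccccc2)cc1` gives 71 nM

Compound 3 carries the highest of the three numbers in this assay. Its nearest neighbour is compound 2, whose value lies within the scatter of that of compound 3, so no order between these two is claimed; compound 1 lies beyond the scatter, with a lower number than compound 3.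

The next member, compound 4 `CCCCCCCCc1ccc(OCC(=O)Cn2nnnc2-c2ccc(C(=O)O)cc2)cc1`, has not been measured. It differs from compound 3 by carboxy in place of hydrogen on an aromatic carbon. Cut one bond further out, the same change reads phenyl to 4-carboxyphenyl.

Within the data shown here, the only measured step that brings in a carboxy group is a 1.6-fold higher number from compound 1 to compound 2 (0.19 log units; within the scatter). Among the measured compounds shown here, that step exchanges pyridin-3-yl for 3-carboxyphenyl on the core of compound 1, which is not the core of compound 3, and no measured pair shows hydrogen to carboxy on the core of compound 3. The bearing is therefore indirect. For the measured compounds named here, since the one related step stayed within the scatter, no step beyond the scatter is expected in this assay, in either direction.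

Compound 4 is accordingly expected near 80 nM, with a range from 30 nM to 250 nM. For compound 4 the expected step is a 1.1-fold higher number from compound 3 to compound 4 (0.05 log units; within the scatter).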

Compound 4, half-maximal inhibitory concentration: 3400 nM
Beside the measured number, compound 4's estimate is 43-fold (1.63 log units) below it; the whole stated range lies below it.
By their numbers in this assay, from the lowest: compounds 1, 2 and 3 (each within the scatter of the next, the first and the last beyond it); then compound 4.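

In this assay, carboxy in place of hydrogen on an aromatic carbon, para to a large group, on the core of compound 3 gives a 48-fold higher number from compound 3 to compound 4 (1.68 log units; beyond the scatter), so this position does not take this change without a large loss of inhibition. The only earlier carboxy-bearing pair gave a 1.6-fold higher number from compound 1 to compound 2 (0.19 log units; within the scatter), so a carboxy group does not bring a step of this size in every compound shown, but that pair differs from this one in its core and in the group replaced, and these differences cannot be separated here. No measurement bearing on the reason for the large step is available, and the result stands as an observation on phenyl to 4-carboxyphenyl on this core alone.

Open, on these data alone, is whether a methyl ester or a primary amide in the same place, para to a large group, would keep the number close to that of compound 3 (71 nM). Also open, as far as these compounds go, is whether any added group there brings a large step or only the carboxy group does, which a methyl group or a fluorine atom in that place would begin to separate.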